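The source may hold more compounds than are shown below. What is called first, only, known or untested is meant among the compounds shown, and "the series" means these compounds.

Measured compounds in a functional assay on CHO cells for positive allosteric modulation of metabotropic glutamate receptor 2 (Homo sapiens), read by scintillation counting and GTPgammaS binding, with a stated time of 30 min; a lower number here means that less compound is needed, a higher number that more compound is needed for the effect:
compound 1 `CCCCn1ccc(-c2ccc(Oc3ccnc(C)c3)cc2)c(C#N)c1=O` — 398 nM
compound 2 `CCCCn1ccc(-c2ccc(Oc3cccnc3C)cc2)c(C#N)c1=O` — 347 nM
compound 3 `CCCCn1ccc(-c2ccc(Oc3ccc(C)nc3C)cc2)c(C#N)c1=O` — 138 nM

Compound 3 stands at the lowest number of the three: the step from compound 1 is a 2.9-fold lower number from compound 1 to compound 3 (0.46 log units; beyond the scatter), the step from compound 2 is a 2.5-fold lower number from compound 2 to compound 3 (0.40 log units; beyond the scatter), while between the other two a 1.1-fold lower number from compound 1 to compound 2 (0.06 log units; within the scatter). Compound 4 `CCCCn1ccc(-c2ccc(Oc3ccc(C)nc3C)c(Cl)c2)c(C#N)c1=O` has not yet been measured. It differs from compound 3 by chloro in place of hydrogen on an aromatic carbon. For the measured compounds named here, none of the measured steps bears on this change; each of them alters the group on the oxygen, not the ring that carries it, so there is no direct precedent. The expected change is therefore small, a 1.2-fold lower number from compound 3 to compound 4 (0.06 log units; within the scatter), with no confident direction. For compound 4 the estimate in this assay is 120 nM, with a range from 40 nM to 400 nM.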

Compound 4, half-maximal effective concentration: 30 nM
For compound 4 the middle estimate is 4.0-fold (0.60 log units) above the measured one; measured number outside the range, below it.
By their numbers in this assay, from the lowest: compound 4; then compound 3; then compounds 2 and 1 (each within the scatter of the next).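

In this assay, chloro in place of hydrogen on the aromatic carbon ortho to the (2,6-dimethylpyridin-3-yl)oxy group gives a 4.6-fold lower number from compound 3 to compound 4 (0.66 log units; beyond the scatter). For the compounds shown here, the earlier steps all altered the group on the oxygen, so this is the first sign that the ring carrying that oxygen also affects the number. Nothing measured here explains the change.

From the compounds shown here alone, whether fluoro, methyl or methoxy at this place would act as chloro does remains open. So does whether chloro would give a similar step with 2-methylpyridin-4-yl or 2-methylpyridin-3-yl on the oxygen.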